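The compounds below may be only part of what the source reports. "The series", "measured", "known", "first", "only" and "open" are said of these compounds alone.

Of the compounds shown here, two built on the same core have been measured in a functional assay on NCI-H1299 cells (Homo sapiens) for antiproliferative activity, read by XTT assay, with a stated time of 72 h; a lower number here means a stronger inhibitor, a higher number a weaker inhibitor. Compound 1 `COc1ccc(-c2cc3ccccc3nc2/C=C/C(=O)c2ccc(O)cc2)cc1` gives 8970 nM in this assay, and compound 2 `COc1ccc(-c2cc3ccccc3nc2/C=C/C(=O)c2ccccn2)cc1` gives 660 nM. Going by the values given here, compound 2 thus holds the lower of the two numbers, and the only measured step, a 14-fold lower number from compound 1 to compound 2 (1.13 log units; beyond the scatter), is the only change seen so far at the carbonyl carbon.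

Compound 3 `COc1ccc(-c2cc3ccccc3nc2/C=C/C(=O)c2ccc(Br)s2)cc1` differs from compound 2 in one place: 5-bromothiophen-2-yl in place of pyridin-2-yl on a carbonyl carbon. Among the compounds with values here, the single measured step that bears on this change is a 14-fold lower number from compound 1 to compound 2 (1.13 log units; beyond the scatter), which shows that exchanging the aryl group on the carbonyl carbon can move this assay by a large amount. That step, however, exchanged 4-hydroxyphenyl for pyridin-2-yl rather than pyridin-2-yl for 5-bromothiophen-2-yl, so it indicates how large such an exchange can be but not its direction here. Within the data shown here, no measured compound carries the 5-bromothiophen-2-yl group. The step of a 3.0-fold higher number from compound 2 to compound 3 (0.48 log units; beyond the scatter) is therefore expected to be a modest rise in the number, with wide uncertainty. For compound 3 the estimate is 2000 nM, within a range from 500 nM to 8000 nM.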

Compound 3, half-maximal inhibitory concentration: 710 nM
Beside the measured number, compound 3's estimate is 2.8-fold (0.45 log units) above it, and the stated range covers the measured number.
By their numbers in this assay, from the lowest: compounds 2 and 3 (each within the scatter of the next); then compound 1.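

In this assay, exchanging the ring held by the carbonyl gives a 1.1-fold higher number from compound 2 to compound 3 (0.03 log units; within the scatter), so a six-membered aromatic ring with a nitrogen and a five-membered aromatic ring with a sulfur and a bromine cannot be told apart here. The large step away from 4-hydroxyphenyl now appears with a second replacement, as a 13-fold lower number from compound 1 to compound 3 (1.10 log units; beyond the scatter), so it is not confined to pyridin-2-yl, and among these three compounds only compound 1, with its 4-hydroxyphenyl group, stands apart. Nothing available explains why the three compounds fall as they do.

From the compounds shown here alone, it remains open whether the separation of compound 1 rests on the hydroxyl group or on the phenyl ring itself, a question that a plain phenyl group or a 4-methoxyphenyl group at this place would address. Going by these compounds, it is equally open whether the bromine contributes anything to compound 3, which a thiophen-2-yl group without bromine would test, and whether a ring carrying an amine or a carboxylic acid would remain level with compound 2 and compound 3.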